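The source may hold more compounds than are shown below. What is called first, only, known or untested is meant among the compounds shown, and "the series" means these compounds.

Compounds measured in an ADME assay on Huh-7 cells (Homo sapiens) for cytotoxicity, read by MTT assay, with a stated time of 48 h; on this read-out higher numbers stand for lower toxicity in this test and lower numbers for higher toxicity in this test:
compound 1 `CN(C)CCCCOC(=O)Nc1ccc(Cn2nc(-c3cnn(C)c3)c3ccccc3c2=O)cc1`: 55900 nM
compound 2 `COc1cccc(-c2nn(Cc3ccc(NC(=O)OCCCCN(C)C)cc3)c(=O)c3ccccc23)c1`: 17600 nM

Compound 2 stands lowest of the two numbers; the nearest is compound 1, and the step of a 3.2-fold lower number from compound 1 to compound 2 (0.50 log units; beyond the scatter) lies beyond the scatter. Compound 3 `CN(C)CCCCOC(=O)Nc1ccc(Cn2nc(-c3ccccc3C#N)c3ccccc3c2=O)cc1` differs from compound 2 by 2-cyanophenyl in place of 3-methoxyphenyl on an aromatic carbon. Within the data shown here, no measured step exchanges these two groups; the only step on hand, a 3.2-fold lower number from compound 1 to compound 2 (0.50 log units; beyond the scatter), swaps a different pair of aryl groups at the same position and gives only a rough sense of how far such a swap can move the number. With nothing closer to go on, the expected step in this assay is a 1.1-fold higher number from compound 2 to compound 3 (0.06 log units; within the scatter), not clearly beyond the scatter in either direction. The value of compound 3 in this assay is therefore estimated at 20000 nM, with a range from 8000 nM to 50000 nM.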

Compound 3, half-maximal cytotoxic concentration: 90700 nM
The estimate for compound 3 lay 4.5-fold (0.66 log units) below the measured number; the measured number lies above the stated range.
By their numbers in this assay, from the lowest: compound 2; then compounds 1 and 3 (each within the scatter of the next).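

In this assay, the aryl group at this aromatic carbon can move the number in either direction: 2-cyanophenyl in place of 3-methoxyphenyl gives a 5.2-fold higher number from compound 2 to compound 3 (0.71 log units; beyond the scatter). By contrast, 2-cyanophenyl in place of 1-methyl-1H-pyrazol-4-yl gives a 1.6-fold higher number from compound 1 to compound 3 (0.21 log units; within the scatter), so among these three groups only the 3-methoxyphenyl of compound 2 stands apart from the other two. No supporting measurement bears on the cause of this difference.

From the compounds shown here alone, it remains open whether the lower number of compound 2 goes with the methoxy group itself or with its place on the phenyl ring, and an unsubstituted phenyl group at this carbon would give a reference for both aryl groups. Also open, going by these compounds, is how the number responds away from this position, for example to a morpholine in place of the dimethylamino group.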